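A few compounds are considered here, and "the series" means these few. Any claim that something is new, unique, unknown or untested is made for them only; others in the source may bear on it.

Working notes on the series. In a functional assay on MCF7 cells (Homo sapiens) for antiproliferative activity, read by MTT assay (a higher number here means a weaker inhibitor, a lower number a stronger inhibitor), compound 1 (`COc1ccc(-c2ccnc(Nc3ccc(Cl)cc3Cl)n2)cc1`) gives 4170 nM as its half-maximal inhibitory concentration. Within the data shown here, the only other measured compound is compound 2 (`Clc1ccc(Nc2nccc(-c3ccc(Cl)cc3Cl)n2)c(Cl)c1`), which gives 3180 nM in the same test. Among the measured compounds shown here, these two values lie within the scatter of each other, so compound 1 stands level with compound 2 on the numbers so far.

The next compound is compound 3 (`Cc1ccc(-c2ccnc(Nc3ccc(Cl)cc3Cl)n2)cc1`), with methyl in place of methoxy on an aromatic carbon, para to a large group (methyl in place of methoxy on an aromatic carbon). For the measured compounds named here, no measured pair differs in one place, so the data offer no direct precedent for this change. No shift beyond the scatter is expected in this assay, in either direction. The expected change, a 1.1-fold lower number from compound 1 to compound 3 (0.04 log units; within the scatter), therefore stays within the scatter. Compound 3 is estimated at 3800 nM with an expected range from 1500 nM to 10000 nM in this test.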

Compound 3, half-maximal inhibitory concentration: > 1000000 nM
Compound 3 was reported as a limit; the forecaster's own chance of this, stated with the estimate: 5%; middle value at least 260-fold (2.42 log units) away from the limit.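

Compound 3 is reported only as a limit, not as a number: the limit of > 1000000 nM in this assay, at which 1 of the 3 values shown sits. Even read as a limit, the result gives the series its first step in one place, an at least 230-fold higher number from compound 1 to compound 3 (2.37 log units; beyond the scatter), so in this assay the exchange of methoxy for methyl on this aromatic carbon, para to a large group, is far from a neutral swap. The earlier compounds shown here offered no pair that could show how strongly the read-out depends on the group at this position.

This single pair cannot separate the part played by the oxygen of methoxy from the part played by the size of the group. On these data alone, how an amine, a hydroxyl or a longer chain such as ethoxy would behave at this same carbon remains open.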